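Lauroyl dipeptide series: guanidine in place of the free amine

The source may report more compounds than this note shows. Statements on the series, on what has been measured and on what is new or still open speak of the compounds shown alone.

Measured:
compound 1, `CCCCCCCCCCCC(=O)N[C@H](CCC(=O)NC(CCCC(N)C(=O)O)C(=O)O)C(=O)O`, 0.027 nM
compound 2, `CCCCCCCCCCCCN(CCCCCCCCCCCC)[C@H](CCC(=O)NC(CCCC(N)C(=O)O)C(=O)O)C(=O)O`, 0.0015 nM

In a functional assay on HEK293 cells for agonist activity at Nucleotide-binding oligomerization domain-containing protein 1 (Homo sapiens), read by spectrophotometry (a higher number here means that more compound is needed for the effect, a lower number that less compound is needed), compound 1 gives 0.027 nM, the higher of the two numbers recorded so far. Compound 2, which carries two dodecyl chains on the nitrogen instead of a lauroyl amide, gives in this assay 0.0015 nM, a lower number that lies beyond the scatter of compound 1. Within the data shown here, no step between these two is calculated, so only the two values speak.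

The next compound keeps the lauroyl amide of compound 1 and alters the far end of the molecule. Compound 3, `CCCCCCCCCCCC(=O)N[C@H](CCC(=O)NC(CCCC(NC(=N)N)C(=O)O)C(=O)O)C(=O)O`, differs from compound 1 by a group of 3 heavy atoms (1 carbon, 2 nitrogen; no ring) in place of a hydrogen atom, on an amine nitrogen. Among the measured compounds shown here, no measured pair shows what such a change does, so the expectation rests on compound 1 alone.

The expected step from compound 1 to compound 3 in this assay is a 1.9-fold higher number from compound 1 to compound 3 (0.27 log units; within the scatter), a modest rise in the number that may not exceed the scatter. Compound 3 is accordingly estimated at 0.05 nM, with a range from 0.01 nM to 0.3 nM.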

Compound 3, half-maximal effective concentration: 0.622 nM
For compound 3 the middle estimate is 12-fold (1.09 log units) below the measured one; the whole stated range lies below it.
By their numbers in this assay, from the lowest: compound 2; then compound 1; then compound 3.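

In this assay, among these compounds, the amine nitrogen at the far end of the molecule proves sensitive: a group of 3 heavy atoms (1 carbon, 2 nitrogen; no ring) in place of a hydrogen atom gives a 23-fold higher number from compound 1 to compound 3 (1.36 log units; beyond the scatter), a large step and the first measured change at this position. The lauroyl amide is the same in both compounds, so the step belongs to the change on the amine nitrogen alone, and in this pair the unsubstituted amine of compound 1 needs less compound for the effect than the substituted nitrogen of compound 3. Nothing at hand accounts for the size of this step.

Among the compounds shown here, still open is whether a smaller group on the same nitrogen, such as a methyl or an acetyl group, brings a step of similar size, or whether only this particular group does. Also open, as far as these compounds go, is whether the same replacement gives a comparable step when two dodecyl chains stand in place of the lauroyl amide, as they do in compound 2.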